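Second methyl on the pendant phenyl ring

The source may report more compounds than this note shows. Statements on the series, on what has been measured and on what is new or still open speak of the compounds shown alone.

Compound 1 `COc1ccc(-c2ccnc(C(=O)Nc3ccc(Oc4ccnc5[nH]ccc45)cc3)c2)cc1` gives 7530 nM in a functional assay on HeLa cells (Homo sapiens) for cytotoxicity, read by MTT assay, with a stated time of 72 h; a higher number here means a weaker inhibitor, a lower number a stronger inhibitor. Compound 2 `Cc1cccc(-c2ccnc(C(=O)Nc3ccc(Oc4ccnc5[nH]ccc45)c(F)c3)c2)c1` gives 10300 nM in this assay; this is the top of the two numbers shown, and the gap to compound 1 lies within the scatter, so the two values cannot be told apart. Among the compounds with values here, the two compounds differ in more than one place, and no single-point step between measured compounds is available, so the size of any one change has not yet been seen. Compound 3 `Cc1ccc(-c2ccnc(C(=O)Nc3ccc(Oc4ccnc5[nH]ccc45)c(F)c3)c2)c(C)c1` differs from compound 2 in one place: 2,4-dimethylphenyl in place of 3-methylphenyl on an aromatic carbon. Within the data shown here, with no comparable step to lean on, a change no larger than the scatter is expected, in no particular direction, as a 1.1-fold lower number from compound 2 to compound 3 (0.06 log units; within the scatter). For compound 3 the estimated value in this assay is 9000 nM, with an expected range from 3500 nM to 25000 nM.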

Compound 3, half-maximal inhibitory concentration: 11900 nM
Compound 3: middle estimate off by 1.3-fold (0.12 log units), on the low side; low and high end bracket the measured number.
By their numbers in this assay, from the lowest: compounds 1, 2 and 3 (each within the scatter of the next).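

Within the data shown here, this is the first single-place step: 2,4-dimethylphenyl in place of 3-methylphenyl on an aromatic carbon, opposite the ring nitrogen, gives a 1.2-fold higher number from compound 2 to compound 3 (0.06 log units; within the scatter) in this assay. At this position, then, a pendant group of 8 heavy atoms and one of 7 cannot be told apart in this assay, so the added methyl has no effect that can be resolved here. Nothing available offers a reason for this result.

Whether any group at this position can move the number beyond the scatter stays open, since both groups shown are methyl-substituted phenyl rings with no hydrogen-bond donors or acceptors. A phenyl ring carrying an amine or a carboxylic acid, or a longer alkyl chain in place of the ring, would put that question to a real test.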